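Working notes: carboxyalkyl chain lengthening in one series

A few compounds are considered here, and "the series" means these few. Any claim that something is new, unique, unknown or untested is made for them only; others in the source may bear on it.

Measured so far:
compound 1 `O=C(O)Cn1nc(Cc2nc3cc(Cl)c(OCC(F)F)cc3[nH]2)c2ccccc2c1=O` — 1.97
compound 2 `C[C@@H](C(=O)O)c1nn(Cc2cn3cc(OCC4CC4)c(Cl)cc3n2)c2ccccc2c1=O` — 2.41

In a physicochemical assay for lipophilicity, at pH 7.4 (on this read-out higher numbers stand for higher lipophilicity and lower numbers for lower lipophilicity), compound 2 holds the highest of the two numbers; compound 1 stands lower, and that gap is beyond the scatter. For the measured compounds named here, no pair here differs in one place, so no measured step is available.

Compound 3 `CCC(C(=O)O)c1nn(Cc2cn3cc(OCC4CC4)c(Cl)cc3n2)c2ccccc2c1=O` is not yet measured. It differs from compound 2 by 1-carboxypropyl in place of 1-carboxyethyl on an aromatic carbon. With one more carbon in the chain, a modest upward step in this assay is expected, probably beyond the scatter. The expected step of a number 0.39 log units higher from compound 2 to compound 3 (beyond the scatter) is a small rise. Compound 3 is expected to give 2.8, within 2.4 to 3.2.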

Compound 3, distribution coefficient: 2.71
Estimate against measurement, compound 3: 0.09 log units above; measured number inside the range.
By their numbers in this assay, from the lowest: compound 1; then compounds 2 and 3 (each within the scatter of the next).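

In this assay, for the compounds shown here, the only single-place step so far, 1-carboxypropyl in place of 1-carboxyethyl on this aromatic carbon, reads a number 0.30 log units higher from compound 2 to compound 3 (within the scatter) and so does not separate the two chains at this position. The 1-carboxyethyl group carries a defined stereocentre and the 1-carboxypropyl group carries none, so this step spans both differences. Nothing measured on these compounds accounts for the step.

As far as these compounds go, whether a longer chain such as 1-carboxybutyl would separate from these two stays open. So does the effect of a primary amide or a tetrazole in place of the carboxylic acid at this position.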